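The source may report more compounds than this note shows. Statements on the series, on what has been measured and on what is new or still open speak of the compounds shown alone.

Working notes on the series. The shared core is that of compound 1 `OC[C@H]1O[C@@H](n2cnc3c(Sc4ccccc4)ncnc32)[C@H](O)[C@@H]1O`, which in an assay on isolated protein for binding affinity to Equilibrative nucleoside transporter 1 (Homo sapiens) (on this read-out lower numbers stand for stronger inhibition and higher numbers for weaker inhibition), gives 91200 nM. Among the measured compounds shown here, compound 2 `Cc1ccc(CSc2ncnc3c2ncn3[C@@H]2O[C@H](CO)[C@@H](O)[C@H]2O)cc1` carries a benzylic sulfur substituent and in this assay gives 457 nM; the step of a 200-fold lower number from compound 1 to compound 2 (2.30 log units; beyond the scatter) is the only single-point comparison measured so far. For the measured compounds named here, compound 3 `OC[C@H]1O[C@@H](n2cnc3c(CSc4c(F)cccc4Cl)ncnc32)[C@H](O)[C@@H]1O` in this assay gives 1510 nM, which places it second highest of the three numbers, nearer to compound 2 than to compound 1; no single-point step links compound 3 to either, so only the values themselves are compared.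

Compound 4 `OC[C@H]1O[C@@H](n2cnc3c(CSc4cccc(Br)c4)ncnc32)[C@H](O)[C@@H]1O` differs from compound 3 in one place: 3-bromophenyl in place of 2-chloro-6-fluorophenyl on a sulfur. Going by the values given here, no measured step bears directly on this change, since the one measured step concerns phenyl against 4-methylbenzyl rather than the substituents of a benzyl ring. Compound 2 and compound 3 show that two differently substituted benzyl groups on the sulfur both give numbers in the same low range, so compound 4 is expected to stay in that range, with a step of a 2.2-fold lower number from compound 3 to compound 4 (0.33 log units; beyond the scatter) that may not exceed the scatter. The estimate for compound 4 in this assay is 700 nM, within 250 nM to 2500 nM.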

Compound 4, half-maximal inhibitory concentration: 363 nM
Compound 4: middle estimate off by 1.9-fold (0.29 log units), on the high side; measured number inside the range.
By their numbers in this assay, from the lowest: compounds 4 and 2 (each within the scatter of the next); then compound 3; then compound 1.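

On a sulfur whose other neighbours are saturated chain carbon, 3-bromophenyl in place of 2-chloro-6-fluorophenyl gives a 4.2-fold lower number from compound 3 to compound 4 (0.62 log units; beyond the scatter) in this assay, the first direct sign that the aryl group on this sulfur alters the number. On the aromatic carbon, ((3-bromophenyl)sulfanyl)methyl in place of (4-methylbenzyl)sulfanyl gives a 1.3-fold lower number from compound 2 to compound 4 (0.10 log units; within the scatter), so these two arrangements are not separated, while the same group in place of phenylsulfanyl gives a 250-fold lower number from compound 1 to compound 4 (2.40 log units; beyond the scatter) and extends the large change seen for compound 2 to a second arrangement. Nothing available accounts for these steps.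

The step to the 3-bromophenyl group exchanges all the ring substituents at once, so the separate contributions of bromine, chlorine and fluorine stay unresolved. Also open, on these data alone, is how an amine or a carboxylic acid in place of the bromine, or a longer chain on the sulfur, would read in this assay.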